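Benzyl to (methoxycarbonyl)methyl at the edge of activity

The source may report more compounds than this note shows. Statements on the series, on what has been measured and on what is new or still open speak of the compounds shown alone.

- Compound 1 `COC(=O)c1[nH]c2cc(OC)ccc2c1C1CCCCC1`: > 100000 nM (a limit of the assay, not a number)
- Compound 2 `COC(=O)c1[nH]c2cc(OC)ccc2c1Cc1ccccc1`: 61600 nM

Among the measured compounds shown here, in a functional assay on RS4-11 cells (Homo sapiens) for antiproliferative activity, read by MTT assay, with a stated time of 48 h (on this read-out higher numbers stand for an effect only at larger amounts of compound and lower numbers for an effect already at smaller amounts), compound 2, at 61600 nM, gives the only number. For compound 1 there is only a limit: the limit of > 100000 nM in this assay, at which 1 of the 2 values shown sits. Compound 3 `COC(=O)Cc1c(C(=O)OC)[nH]c2cc(OC)ccc12` carries methoxycarbonyl in place of phenyl on a saturated chain carbon bound to an aromatic carbon. For the measured compounds named here, the sole measured step, an at least 1.6-fold lower number from compound 1 to compound 2 (0.21 log units; that floor lies within the scatter), bears on this change only indirectly. No step beyond the scatter is therefore expected in this assay. The expected step is a 1.3-fold higher number from compound 2 to compound 3 (0.11 log units; within the scatter). Compound 3 is estimated at 80000 nM, with an expected range of 30000 nM to 200000 nM.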

Compound 3, half-maximal effective concentration: > 100000 nM
Compound 3 gave a limit, no number; the forecaster's own chance of this, stated with the estimate: 40%; at least 1.2-fold (0.09 log units) between middle value and limit.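

In this assay, exchanging the benzyl for (methoxycarbonyl)methyl on the aromatic carbon gives an at least 1.6-fold higher number from compound 2 to compound 3 (0.21 log units; that floor lies within the scatter) and yields no measurable number, so this ester chain, unlike the benzyl, joins cyclohexyl at the limit of the assay. The step between compound 1 and compound 3 cannot be read. Among the compounds shown here, compound 2 thus remains the only compound with a number, and the other two compounds end at the same limit: the limit of > 100000 nM in this assay, at which 2 of the 3 values shown sit.

Going by these compounds, whether an amine or a carboxylic acid on this saturated chain carbon would give a number stays open. So does the effect of a longer chain ending in phenyl.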